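Thiophene to hydroxynitrophenyl on the enone chain of compound 2

The source may hold more compounds than are shown below. What is called first, only, known or untested is meant among the compounds shown, and "the series" means these compounds.

Measured compounds:
compound 1 `Cc1ccsc1/C=C(/SCc1ccc(Cl)cc1)C(=O)c1ccc(Br)cc1`, 25000 nM in a functional assay on DU-145 cells (Homo sapiens) for inhibition, read by trypan blue exclusion, with a stated time of 96 h; a higher number here means a weaker inhibitor of growth, a lower number a stronger inhibitor of growth
compound 2 `Cc1ccsc1/C=C(/SCc1ccc(Cl)cc1)C(=O)c1ccc(Cl)cc1`, 50000 nM in this assay
compound 3 `Cc1ccc(CS/C(=C/c2sccc2C)C(=O)c2ccc(Cl)cc2)cc1`, 10000 nM in this assay

In this assay compound 2 sits where the step of a 2.0-fold higher number from compound 1 to compound 2 (0.30 log units; within the scatter) puts it, within the scatter of compound 1, while the step of a 5.0-fold lower number from compound 2 to compound 3 (0.70 log units; beyond the scatter) separates it from compound 3 beyond the scatter. Compound 4 `O=C(/C(=C\c1ccc(O)c([N+](=O)[O-])c1)SCc1ccc(Cl)cc1)c1ccc(Cl)cc1` arises from compound 2 by the change (4-hydroxy-3-nitrophenyl in place of 3-methylthiophen-2-yl on a double-bonded chain carbon bound to a double-bonded chain carbon). Neither measured step touches this chain carbon; the step of a 2.0-fold higher number from compound 1 to compound 2 (0.30 log units; within the scatter) and the step of a 5.0-fold lower number from compound 2 to compound 3 (0.70 log units; beyond the scatter) concern groups on the aromatic carbons, so nothing measured bears on the change. Compound 4 is therefore expected to show no step beyond the scatter, with wide uncertainty: the estimated step is a 1.7-fold lower number from compound 2 to compound 4 (0.22 log units; within the scatter). Compound 4 is estimated at 30000 nM, ranging from 8000 nM to 100000 nM.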

Compound 4, concentration for 50% growth inhibition: 10000 nM
Beside the measured number, compound 4's estimate is 3.0-fold (0.48 log units) above it; measured number inside the range.
By their numbers in this assay, from the lowest: compounds 3 and 4 (each within the scatter of the next); then compounds 1 and 2 (each within the scatter of the next).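

In this assay the double-bonded chain carbon proves to be a place where a change can move the number, with a 5.0-fold lower number from compound 2 to compound 4 (0.70 log units; beyond the scatter) when 4-hydroxy-3-nitrophenyl replaces 3-methylthiophen-2-yl. Among these compounds, the earlier steps concerned only groups on aromatic carbons, so this is the first reading at this chain carbon. Nothing available accounts for the step.

The compounds shown leave open whether the hydroxy or the nitro group goes with this step, and how a plain phenyl or an amine would read on this chain carbon.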